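Replacing the chloro group of compound 2 with hydrogen

The source may hold more compounds than are shown below. What is called first, only, known or untested is meant among the compounds shown, and "the series" means these compounds.

Compound 1 `CN[C@@H](C)c1ccc(N2CC[C@H](NS(=O)(=O)c3ccc4cc(Cl)ccc4c3)C2=O)c(F)c1`: 2.4 L/kg
Compound 2 `O=C1[C@@H](NS(=O)(=O)c2ccc3c(Cl)c[nH]c3c2)CCN1c1ccc2c(c1)CCNC2`: 2.9 L/kg

In an in vivo ADME assay on the whole organism (strain Sprague-Dawley) for pharmacokinetics, with Rattus norvegicus as the target (a higher number here means that more of the compound sits outside the plasma, a lower number that more of the compound stays in the plasma), compound 1 gives 2.4 L/kg and compound 2 gives 2.9 L/kg. These two values lie within the usual scatter of each other, so compound 2 stands level with compound 1. Among the compounds with values here, the two compounds differ in more than one place, and no measured step isolates a single group.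

Compound 3 `O=C1[C@@H](NS(=O)(=O)c2ccc3cc[nH]c3c2)CCN1c1ccc2c(c1)CCNC2` differs from compound 2 in one place: hydrogen in place of chloro on an aromatic carbon. Hydrogen takes the place of chloro on an aromatic carbon, which turns the 3-chloro-1H-indol-6-yl group into 1H-indol-6-yl. Within the data shown here, no measured pair shows the effect of this change in this assay, so the expectation rests on compound 2 and its 2.9 L/kg. A step within the scatter is expected, with a slight lean toward a lower number and no firm direction. The expected change is a 1.2-fold lower number from compound 2 to compound 3 (0.08 log units; within the scatter). For compound 3 the expected value is 2.4 L/kg, with an estimated range from 1.2 L/kg to 4.8 L/kg.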

Compound 3, volume of distribution at steady state: 4.1 L/kg
Compound 3: the middle estimate sits 1.7-fold (0.23 log units) below what was measured, and the stated range covers the measured number.
By their numbers in this assay, from the lowest: compounds 1, 2 and 3 (each within the scatter of the next).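

In this assay, the change from 3-chloro-1H-indol-6-yl to 1H-indol-6-yl gives a 1.4-fold higher number from compound 2 to compound 3 (0.15 log units; within the scatter). This is the only step among the compounds shown that isolates a single group, and it places hydrogen and chloro on this aromatic carbon of the five-membered ring level with each other in this read-out. In this pair, then, the volume of distribution does not depend measurably on whether the chloro group is present at this position. Nothing measured alongside these compounds bears on this step.

The compounds shown leave open how a fluoro, a methyl or a nitrile group on this same aromatic carbon would read in this assay, as hydrogen and chloro are the only two groups seen there so far. Within the data shown here, they also leave open whether the same exchange would stay within the scatter on a different core, as this single pair offers the only view of the change.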